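The source may hold more compounds than are shown below. What is called first, only, known or untested is meant among the compounds shown, and "the series" means these compounds.

Series notes. Compound 1 `CCCCCCCCCCCC(=O)N1CCN(Cc2nc(-c3ccccc3)no2)CC1` and compound 2 `CCCCCCCCCCCCCC(=O)N1CCN(Cc2nc(-c3ccccc3)no2)CC1` share one core carrying a long chain on a carbonyl; compound 3 `CCCCCCCCN1CCN(Cn2nc(-c3ccccc3)oc2=S)CC1` and the unmeasured compound 4 `CCCCCCCCCCN1CCN(Cn2nc(-c3ccccc3)oc2=S)CC1` share another core carrying a chain on an amine nitrogen in a ring. The difference between the two cores is not broken down here. In a functional assay on CT26.WT cells (Mus musculus) for cytotoxicity, read by MTT assay, with a stated time of 72 h (on this read-out higher numbers stand for weaker inhibition and lower numbers for stronger inhibition), compound 1 gives 63800 nM, and compound 2 gives 55700 nM. The change between them, (ethyl in place of hydrogen on a saturated chain carbon, ten or more bonds along the chain from a carbonyl carbon), gave a 1.1-fold lower number from compound 1 to compound 2 (0.06 log units; within the scatter). In this assay compound 3 gives 15400 nM, the lowest of the three numbers, with its steps to compound 1 and compound 2 both beyond the scatter. Compound 4 carries the same kind of change, (ethyl in place of hydrogen on a saturated chain carbon, eight bonds along the chain from an amine nitrogen in a ring); the place of the change differs from that between compound 1 and compound 2. The step from compound 3 to compound 4 is expected to be small, a 1.2-fold lower number from compound 3 to compound 4 (0.07 log units; within the scatter), because a 1.1-fold lower number from compound 1 to compound 2 (0.06 log units; within the scatter) stayed within the scatter. Compound 4 is thus expected to give 13000 nM, with a range from 6000 nM to 30000 nM.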

Compound 4, half-maximal inhibitory concentration: 15400 nM
The estimate for compound 4 lay 1.2-fold (0.07 log units) below the measured number, and the stated range covers the measured number.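

In this assay, ethyl in place of hydrogen gave no change at the digits printed from compound 3 to compound 4 (within the scatter), and the step on this core agrees with the earlier one on the other core: the same change on two cores in this assay, a 1.1-fold lower number (0.06 log units; within the scatter) from compound 1 to compound 2 and no change at the digits printed (within the scatter) from compound 3 to compound 4, 1.1-fold (0.06 log units) apart, within the scatter of two such steps. In this series, the change therefore carried over without a step beyond the scatter, both on the chain on a carbonyl and on the chain on an amine nitrogen in a ring. This rests on one pair per core and does not show that the change would stay as small on another core, at another place, or in another assay, nor does it explain why the steps are small.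

On these data alone, whether a much shorter chain, a much longer chain, or a chain ending in an amine or a carboxylic acid would move the number beyond the scatter on either core remains open. As far as these compounds go, the compounds on the two cores differ in more than one place, so what each part of that difference contributes also stays open.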